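A Side-Chain Swap on a Compound at the Assay Limit

This account rests on a few compounds, and the source may have more. Where it says the series, first, only, none or still open, it means among the compounds named here.

Measured in a functional assay on HepG2 cells (Homo sapiens), read by MTT assay, with a stated time of 48 h; a lower number here means a stronger inhibitor, a higher number a weaker inhibitor:
- Compound 1 `CCN(CC)CCNC(=O)c1ccc(C(CC)(CC)c2ccc(OCC(=O)C(C)(C)C)c(C)c2)n1CC`: 620 nM
- Compound 2 `CCOC(=O)CN(C)C(=O)c1ccc(C(CC)(CC)c2ccc(OCC(O)C(C)(C)C)c(C)c2)n1CC`: > 50000 nM

Compound 2 stands at > 50000 nM, and this is a limit of the assay, not a number. It gives no exact potency to start from.

Compound 3 `CCN(CC)CCNC(=O)c1ccc(C(CC)(CC)c2ccc(OCC(O)C(C)(C)C)c(C)c2)n1CC` is made from compound 2 by one change on a carbonyl carbon: (2-(diethylamino)ethyl)amino in place of ((ethoxycarbonyl)methyl)(methyl)amino ((2-(diethylamino)ethyl)amino in place of ((ethoxycarbonyl)methyl)(methyl)amino on a carbonyl carbon).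

Compound 1 carries the same (2-(diethylamino)ethyl)amino group and gives 620 nM in this assay. For the measured compounds named here, this single compound is the only guide, so the expected range stays wide.

A large step toward stronger inhibition, well beyond the scatter, is expected: an at least 33-fold lower number from compound 2 to compound 3 (1.52 log units; beyond the scatter).

For compound 3 the estimate is 1500 nM, with an expected range of 300 nM to 8000 nM.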

Compound 3, half-maximal inhibitory concentration: 490 nM
For compound 3 the middle estimate is 3.1-fold (0.49 log units) above the measured one, within the range that was stated.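

Replacing ((ethoxycarbonyl)methyl)(methyl)amino with (2-(diethylamino)ethyl)amino on this carbonyl carbon gives an at least 100-fold lower number from compound 2 to compound 3 (2.00 log units; beyond the scatter), so the group at this position separates a measurable result in this assay from none. The true size of that step stays unknown, since compound 2 stands at a limit of the assay and not at a number: the limit of > 50000 nM in this assay, at which 1 of the 3 values shown sits.

The other change, 1-hydroxy-2,2-dimethylpropyl in place of (tert-butyl)carbonyl, gives a 1.3-fold lower number from compound 1 to compound 3 (0.10 log units; within the scatter), so with the (2-(diethylamino)ethyl)amino group present it makes no difference that can be told from the scatter.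

Which part of the (2-(diethylamino)ethyl)amino group matters remains open, and a shorter chain ending in a dimethylamino group or a morpholine ring could help to separate them. Also open, on these data alone, is whether the ethyl ester of compound 2 could be replaced by a carboxylic acid with a different result.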